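Compound 4: 4-methoxybenzyl in place of 4-methoxyphenyl

The source may report more compounds than this note shows. Statements on the series, on what has been measured and on what is new or still open speak of the compounds shown alone.

Compound 1 `COc1cc(/C=C/c2nc(NC3CC3)c3sccc3n2)cc(OC)c1OC`: in a functional assay on L02 cells (Homo sapiens) for inhibition, read by Griess assay, with stated times of 1 h and 24 h (on this read-out lower numbers stand for stronger inhibition and higher numbers for weaker inhibition), compound 1 gives only the limit > 1000000 nM.
Compound 2 `COc1cc(/C=C/c2nc(N3CCN(C)CC3)c3sccc3n2)cc(OC)c1OC`: in this assay compound 2 gives only the limit > 1000000 nM.
Compound 3 `COc1ccc(Nc2nc(/C=C/c3cc(OC)c(OC)c(OC)c3)nc3ccsc23)cc1`: in this assay compound 3 gives 279000 nM.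

Compound 3 is the only one of the three with a number rather than a limit in this assay, and the two limits are the limit of > 1000000 nM in this assay, at which 2 of the 3 values shown sit. The steps leading to it are an at least 3.5-fold lower number from compound 1 to compound 3 (0.55 log units; beyond the scatter) and an at least 3.5-fold lower number from compound 2 to compound 3 (0.55 log units; beyond the scatter); both replace a small or saturated group on the shared core with an aromatic one, and both are at least modest.

Compound 4 `COc1ccc(CNc2nc(/C=C/c3cc(OC)c(OC)c(OC)c3)nc3ccsc23)cc1` differs from compound 3 by 4-methoxybenzyl in place of 4-methoxyphenyl on a nitrogen on an aromatic ring. Among the compounds with values here, no measured pair compares an aryl group with the corresponding benzyl group on that nitrogen, so the two steps into compound 3 set only a loose frame: the aromatic group is retained, and a drift back toward the limits of compound 1 and compound 2 cannot be excluded. Compound 4 is therefore expected to give a step of a 1.6-fold higher number from compound 3 to compound 4 (0.21 log units; within the scatter), with a fair chance that only a limit is reported. Compound 4 is estimated at 450000 nM, between 150000 nM and 1500000 nM.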

Compound 4, half-maximal inhibitory concentration: > 1000000 nM
Compound 4 was reported as a limit (the forecaster's own chance of this, stated with the estimate: 40%); middle value at least 2.2-fold (0.34 log units) away from the limit.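

In this assay, within the data shown here, the earlier compounds showed that 4-methoxyphenyl on this nitrogen gave a number where cyclopropyl did not; the new result shows that an aromatic ring on this nitrogen does not by itself keep that number, with an at least 3.5-fold higher number from compound 3 to compound 4 (0.55 log units; beyond the scatter). The change is small in what is counted, from 8 to 9 heavy atoms, with the same six-membered aromatic ring and the same count of hydrogen-bond donors and acceptors, yet the step lies beyond the scatter. Compound 3 therefore remains the only compound here with a number rather than a limit: the limit of > 1000000 nM in this assay, at which 3 of the 4 values shown sit.

As far as these compounds go, the steps from compound 1 and from compound 2 to compound 4 cannot be read, and how far compound 4 lies from compound 3 stays open, since its value is only a limit. Also open, from the compounds shown here alone, is whether a phenyl ring on this nitrogen carrying a carboxylic acid or a dimethylamino group in place of methoxy would move the number from that of compound 3.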